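This account rests on a few compounds, and the source may have more. Where it says the series, first, only, none or still open, it means among the compounds named here.

In a physicochemical assay for solubility, in phosphate buffer, with a stated time of 18 h (on this read-out lower numbers stand for lower solubility and higher numbers for higher solubility), compound 1 `CC(C)(C)c1nc(-c2ccc[nH]2)c2cc(C(N)=O)c(N)nc2n1` gives 130000 nM and compound 2 `Cc1nc(C(C)(C)C)nc2nc(N)c(C#N)c(N)c12` gives 37000 nM. Compound 3 `CC(C)(C)c1nc(-c2nccs2)c2c(N)c(C#N)c(N)nc2n1` gives < 1500 nM, which is a limit and not a number, and it stands at the limit of < 1500 nM in this assay, at which 1 of the 3 values shown sits. Compound 4 `CC(C)(C)c1nc(-c2cnccn2)c2c(N)c(C#N)c(N)nc2n1` carries pyrazin-2-yl in place of the 1,3-thiazol-2-yl of compound 3 on an aromatic carbon (pyrazin-2-yl in place of 1,3-thiazol-2-yl on an aromatic carbon). For the measured compounds named here, the one measured step at this place is an at least 24-fold lower number from compound 2 to compound 3 (1.39 log units; beyond the scatter), large and beyond the scatter, with 1,3-thiazol-2-yl in place of methyl. That step leaves from methyl and not from an aromatic ring, so no step beyond the scatter is expected in this assay. The expected step is a number no lower from compound 3 to compound 4 (the limit leaves the size open). For compound 4 the estimate is 1500 nM, with an expected range from 500 nM to 8000 nM.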

Compound 4, solubility: 86000 nM
Estimate against measurement, compound 4: 57-fold (1.76 log units) below; measured number outside the range, above it.
By their numbers in this assay, from the lowest: compound 2; then compounds 4 and 1 (each within the scatter of the next). At a limit, below all of these: compound 3.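

In this assay, an aromatic ring at this place does not by itself bring the number down: the change from 1,3-thiazol-2-yl to pyrazin-2-yl gives an at least 57-fold higher number from compound 3 to compound 4 (1.75 log units; beyond the scatter), and measured against methyl the pyrazin-2-yl ring gives a 2.3-fold higher number from compound 2 to compound 4 (0.37 log units; beyond the scatter). The two rings thus move the number in opposite directions from methyl, so the low end belongs to 1,3-thiazol-2-yl alone among these groups. The figure for compound 3 is a limit: the limit of < 1500 nM in this assay, at which 1 of the 4 values shown sits.

From the compounds shown here alone, how far compound 3 truly lies under that limit stays open. So does the outcome with a plain phenyl ring or an amine at this place.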